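The compounds below may be only part of what the source reports. "The series", "measured", "known", "first", "only" and "open" are said of these compounds alone.

Among the compounds with values here, compound 1 `CCCc1c(C(=O)N[C@@H](C)c2ccc(C(=O)O)cc2)nnn1Cc1ccc(C(F)(F)F)cc1` and compound 2 `C[C@H](NC(=O)c1c(C(F)(F)F)nnn1Cc1ccc(F)cc1)c1ccc(C(=O)O)cc1` share one core and are the two measured members of this set. In a functional assay on CHO cells for antagonist activity at prostaglandin E2 receptor EP4 subtype (Homo sapiens), read by calcium flux, with a stated time of 15 min (on this read-out higher numbers stand for weaker inhibition and lower numbers for stronger inhibition), compound 1 gives only a limit, > 10000 nM. In this assay, within the data shown here, compound 2 gives 2320 nM, the only number among the values shown. The remaining value sits at the limit of > 10000 nM in this assay, at which 1 of the 2 values shown sits. Compound 3 `C[C@H](NC(=O)c1c(C(F)(F)F)nnn1Cc1cccc(C(F)(F)F)c1)c1ccc(C(=O)O)cc1` is not yet measured; it differs from compound 2 by 3-(trifluoromethyl)phenyl in place of 4-fluorophenyl on a saturated chain carbon bound to an aromatic nitrogen. Among the measured compounds shown here, no step between measured compounds is known, so no direction is supported, and a step of no more than the usual scatter is expected, a 1.2-fold lower number from compound 2 to compound 3 (0.06 log units; within the scatter). Compound 3 is accordingly estimated at 2000 nM, within 500 nM to 8000 nM.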

Compound 3, half-maximal inhibitory concentration: 1970 nM
For compound 3 the middle estimate is 1.0-fold (0.01 log units) above the measured one; measured number inside the range.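

In this assay, 3-(trifluoromethyl)phenyl in place of 4-fluorophenyl on a saturated chain carbon bound to an aromatic nitrogen gives a 1.2-fold lower number from compound 2 to compound 3 (0.07 log units; within the scatter). This position therefore accepts the group of 10 heavy atoms in place of the group of 7 with no step beyond the scatter. Nothing measured here bears on why the two compounds read alike. The compounds shown do not separate the swap of fluorine for trifluoromethyl from the different placing of that group on the ring. As far as these compounds go, whether an amine or a longer chain in place of the benzyl group would be accepted at this position also stays open.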